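Carbamate ester variation against liver S9 stability

This account rests on a few compounds, and the source may have more. Where it says the series, first, only, none or still open, it means among the compounds named here.

Compound 1 `C[C@@H]1CN(C(=O)c2nc(Nc3cc(C4CC4)[nH]n3)c3cc(Cl)ccc3n2)CCN1C(=O)OC(C)(C)C` is the reference point of the pair measured so far. In an ADME assay on S9 fraction from liver (Rattus norvegicus), read by LC-MS, with a stated time of 60 min, at 37 degrees C (on this read-out lower numbers stand for a less stable compound and higher numbers for a more stable compound), compound 1 gives 71.3%, the highest of the two numbers in hand. Compound 2 `CC(OC(=O)C(C)C)OC(=O)N1CCN(C(=O)c2nc(Nc3cc(C4CC4)[nH]n3)c3cc(Cl)ccc3n2)C[C@H]1C` differs from it on an oxygen next to a carbonyl group, carrying 1-((isopropylcarbonyl)oxy)ethyl in place of tert-butyl; in this assay compound 2 gives 11%. Going by the values given here, the single measured step, a number 60.3 percentage points lower from compound 1 to compound 2 (beyond the scatter), is large and beyond the scatter.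

Compound 3 `CC(C)C(=O)OCOC(=O)N1CCN(C(=O)c2nc(Nc3cc(C4CC4)[nH]n3)c3cc(Cl)ccc3n2)C[C@H]1C` is not yet measured. Its change from compound 1 is ((isopropylcarbonyl)oxy)methyl in place of tert-butyl on an oxygen next to a carbonyl group. The entering ((isopropylcarbonyl)oxy)methyl group is the close relative of the 1-((isopropylcarbonyl)oxy)ethyl group of compound 2, so the step from compound 1 to compound 2 is the one that bears on it. A large drop in the same direction is therefore expected, a number 56.3 percentage points lower from compound 1 to compound 3 (beyond the scatter). Compound 3 is expected to give 15% in this assay, with a range of 3% to 40%.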

Compound 3, percent of the compound remaining: 14%
Compound 3: middle estimate off by 1 percentage points, on the high side; low and high end bracket the measured number.
By their numbers in this assay, from the lowest: compounds 2 and 3 (each within the scatter of the next); then compound 1.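

With ((isopropylcarbonyl)oxy)methyl on the oxygen next to a carbonyl group, the large fall recurs, a number 57.3 percentage points lower from compound 1 to compound 3 (beyond the scatter), so the low number of compound 2 does not depend on the methyl of its 1-((isopropylcarbonyl)oxy)ethyl group. Hydrogen in place of methyl on the saturated chain carbon bound to two oxygens gives a number 3 percentage points higher from compound 2 to compound 3 (within the scatter), so in this assay this change does not separate the two compounds. Nothing in hand explains why both entering groups read so far from tert-butyl.

Still open, as far as these compounds go, is how a plain ethyl group on that oxygen would read, with no ester in the entering group, and whether a longer chain in place of the isopropyl of the ester would change the number. The percent remaining also does not tell which part of compound 2 or compound 3 is lost during the incubation.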